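The compounds below may be only part of what the source reports. "The series", "measured", "known", "first", "only" and "open" are said of these compounds alone.

In a physicochemical assay for solubility, at pH 7.4 (a lower number here means a less soluble compound, a higher number a more soluble compound), compound 3 `CN(C)c1nc(NCc2ccc(NC(=O)c3ccc(F)cc3)cc2)c2ccc(CO)cc2n1` gives 4 ug/mL as the lower of the two numeric values in the series. Compound 2 `CC(O)c1ccc2c(NCc3ccc(NC(=O)c4ccc(F)cc4)cc3)nc(N(C)C)nc2c1` gives 18 ug/mL as the other numeric value. Compound 1 `CN(C)c1nc(NCc2ccc(NC(=O)c3ccc(F)cc3)cc2)c2ccc(I)cc2n1` gives > 100 ug/mL in this series, and that is a limit of the assay and not a number.

Going by the values given here, compound 4 `C=Cc1ccc2c(NCc3ccc(NC(=O)c4ccc(F)cc4)cc3)nc(N(C)C)nc2c1`, not yet measured, carries vinyl in place of hydroxymethyl on an aromatic carbon of the shared core vinyl in place of hydroxymethyl on an aromatic carbon as the single structural change from compound 3. Among the compounds with values here, no measured step ends in vinyl, so the evidence is indirect. Hydroxymethyl in place of iodo gave an at least 25-fold lower number from compound 1 to compound 3 (1.39 log units; beyond the scatter) as a large step, and 1-hydroxyethyl in place of iodo gave an at least 5.5-fold lower number from compound 1 to compound 2 (0.74 log units; beyond the scatter) as a smaller one. Removing the methyl gave a 4.5-fold lower number from compound 2 to compound 3 (0.65 log units; beyond the scatter) as a modest step. Vinyl, like iodo in compound 1, enters without oxygen, so the two steps away from iodo are read in reverse, with caution. Vinyl is not iodo, and the starting value is only a limit. An estimated 5.0-fold higher number from compound 3 to compound 4 (0.70 log units; beyond the scatter) is therefore expected in this assay as a rise beyond the scatter. For compound 4 the expected value is 20 ug/mL as the estimate, with an estimated range from 6 ug/mL to 90 ug/mL in this measurement.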

Compound 4, solubility: 1 ug/mL
Compound 4: the middle estimate sits 20-fold (1.30 log units) above what was measured; measured number below the stated range.
By their numbers in this assay, from the lowest: compound 4; then compound 3; then compound 2. At a limit, above all of these: compound 1.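

In this assay, vinyl in place of hydroxymethyl on an aromatic carbon gave a 4.0-fold lower number from compound 3 to compound 4 (0.60 log units; beyond the scatter), and vinyl in place of 1-hydroxyethyl gave an 18-fold lower number from compound 2 to compound 4 (1.26 log units; beyond the scatter), so at this position losing the oxygen did not move the number back towards compound 1. Iodo and vinyl both lack oxygen, yet they stand at the two ends of the series, with the oxygen-bearing compound 2 and compound 3 between them, and the direct exchange gave an at least 100-fold lower number from compound 1 to compound 4 (2.00 log units; beyond the scatter). That last step is only a bound, as the value of compound 1 is a limit and not a number: the limit of > 100 ug/mL in this assay, at which 1 of the 4 values shown sits.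

The compounds shown do not tell whether the low number of compound 4 goes with the double bond of vinyl or with any small carbon-only group here, and ethyl at this aromatic carbon would separate the two readings. From the compounds shown here alone, an aminomethyl group or a carboxylic acid at the same place is also open, as is how far the number of compound 1 lies past its limit.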